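The source may hold more compounds than are shown below. What is called first, only, known or untested is meant among the compounds shown, and "the series" means these compounds.

Working notes on the series in a functional assay on A549 cells (Homo sapiens) for antiproliferative activity, read by sulforhodamine B assay, with a stated time of 72 h; on this read-out lower numbers stand for stronger inhibition and higher numbers for weaker inhibition. Of the compounds shown here, three have numbers so far. Compound 1 `COc1ncc(-c2ccc3ncnc(Nc4ccc(OCCO)cc4)c3c2)cc1NS(=O)(=O)c1ccc(F)cc1F` gives 2690 nM. Compound 2 `COc1ncc(-c2ccc3ncnc(Nc4ccc(OCCO)nc4)c3c2)cc1NS(C)(=O)=O` gives 5080 nM. Compound 3 `COc1ncc(-c2ccc3ncnc(Nc4ccc(OCCO)nc4)c3c2)cc1NS(=O)(=O)c1ccc(F)cc1F` gives 4120 nM. Compound 2 has the highest of the three numbers, but its gaps to compound 3 and to compound 1 both lie within the scatter, so no order among the three is established.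

The next compound, compound 4 `COC(=O)CCn1cc(Nc2ncnc3ccc(-c4cnc(OC)c(NS(C)(=O)=O)c4)cc23)cn1`, differs from compound 2 in one place: 1-(2-(methoxycarbonyl)ethyl)-1H-pyrazol-4-yl in place of 6-(2-hydroxyethoxy)pyridin-3-yl on a nitrogen on an aromatic ring. Among the measured compounds shown here, two measured steps bear on this. The swap of the aryl group on the same nitrogen, a 1.5-fold higher number from compound 1 to compound 3 (0.19 log units; within the scatter), changed nothing beyond the scatter. The change at the sulfonyl sulfur, a 1.2-fold lower number from compound 2 to compound 3 (0.09 log units; within the scatter), also stayed within the scatter, though it does not touch the amine substituent. The entering pyrazolyl group with its methoxycarbonylethyl chain is further from anything measured than the earlier phenyl-to-pyridyl swap, so the range is widened accordingly. On the basis of that aryl swap, no step beyond the scatter is expected in this assay, and compound 4 is estimated at 4500 nM with a range of 1500 nM to 14000 nM. The expected step of a 1.1-fold lower number from compound 2 to compound 4 (0.05 log units; within the scatter) is therefore small.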

Compound 4, half-maximal inhibitory concentration: 2990 nM
Estimate against measurement, compound 4: 1.5-fold (0.18 log units) above; the measured number falls inside the stated range.
By their numbers in this assay, from the lowest: compounds 1, 4, 3 and 2 (each within the scatter of the next).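

The step of a 1.7-fold lower number from compound 2 to compound 4 (0.23 log units; within the scatter) in this assay reaches further than the earlier aryl swap on this nitrogen: a six-membered aromatic ring gives way to a five-membered one with 2 hetero atoms, and the hydroxyl-bearing 2-hydroxyethoxy chain gives way to a 2-(methoxycarbonyl)ethyl chain with no hydrogen-bond donor. Even so, this larger change stays within the scatter, so with methyl on the sulfonyl sulfur, neither the six-membered ring nor the hydrogen-bond donor of the 6-(2-hydroxyethoxy)pyridin-3-yl group is shown to be needed for the read-out in this assay. No measurement at hand accounts for the size of this step or connects it to any property of either group.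

The four compounds leave open what a carboxylic acid, a primary amide or a dimethylamino group in place of the methoxycarbonyl group would do, and whether a longer chain on the pyrazole nitrogen would move the number beyond the scatter. Also open, going by these compounds, is whether the 1-(2-(methoxycarbonyl)ethyl)-1H-pyrazol-4-yl group gives a similar number with 2,4-difluorophenyl on the sulfonyl sulfur.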